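Moving the methyl around the aryl ring

The source may report more compounds than this note shows. Statements on the series, on what has been measured and on what is new or still open speak of the compounds shown alone.

Compound 2 `O=C(c1ccc(-c2nc(-c3ccc(Cl)cc3Cl)no2)s1)C(F)(F)F` gives 240 nM in an assay for inhibition of histone deacetylase 4 (Homo sapiens) (on this read-out higher numbers stand for weaker inhibition and lower numbers for stronger inhibition), the higher of the two numbers recorded so far. Among the compounds with values here, its only measured neighbour, compound 1 `Cc1ccc(-c2noc(-c3ccc(C(=O)C(F)(F)F)s3)n2)cc1`, gives 110 nM in this assay, and the step between them is a 2.2-fold higher number from compound 1 to compound 2 (0.34 log units; beyond the scatter). Compound 3 `Cc1cccc(-c2noc(-c3ccc(C(=O)C(F)(F)F)s3)n2)c1` has not yet been measured. It differs from compound 2 by 3-methylphenyl in place of 2,4-dichlorophenyl on an aromatic carbon. Within the data shown here, only one measured step bears on this change: the move from compound 1 to compound 2, which exchanged a methylphenyl for the dichlorophenyl and gave a 2.2-fold higher number from compound 1 to compound 2 (0.34 log units; beyond the scatter), modest but beyond the scatter. Among the measured compounds shown here, compound 3 undoes that exchange in part, restoring a methylphenyl, though with the methyl placed elsewhere on the ring than in compound 1, and no measured compound shows what that shift alone does. The expectation is therefore a return toward the number of compound 1, a modest step downward, a 1.6-fold lower number from compound 2 to compound 3 (0.20 log units; within the scatter), with the unknown effect of the altered methyl placement widening the range. Compound 3 is accordingly expected to give about 150 nM in this assay, between 60 nM and 400 nM.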

Compound 3, half-maximal inhibitory concentration: 280 nM
Compound 3: middle estimate off by 1.9-fold (0.27 log units), on the low side; the measured number falls inside the stated range.
By their numbers in this assay, from the lowest: compound 1; then compounds 2 and 3 (each within the scatter of the next).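

In this assay, the aryl position on the carbon between the two ring nitrogen atoms proves sensitive to where the methyl sits, not only to whether a methylphenyl is present: moving from 4-methylphenyl to 3-methylphenyl gives (a 2.5-fold higher number from compound 1 to compound 3 (0.41 log units; beyond the scatter)), a step that is modest but real, and the only one shown that changes the methyl's placement alone. The 3-methylphenyl and 2,4-dichlorophenyl groups cannot be told apart here (a 1.2-fold higher number from compound 2 to compound 3 (0.07 log units; within the scatter)), so restoring a methylphenyl does not in itself recover the number of compound 1, which remains the strongest inhibitor of the three, with both of its steps beyond the scatter. Among these three compounds, then, the 4-methylphenyl group stands apart, while two quite different groups, one with chlorine and one with a methyl, give numbers that cannot be separated.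

No measurement offered here explains why the placement of the methyl should matter at this position. Also open, going by these compounds, is how an unsubstituted phenyl, a methoxy group or an amine on this ring would compare, and whether a single chlorine would follow compound 1 or compound 2.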